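From 4-methoxyphenyl to 3-methoxyphenyl in compound 3

The source may report more compounds than this note shows. Statements on the series, on what has been measured and on what is new or still open speak of the compounds shown alone.

Compound 1 `Cn1cc(C2CC(c3ccccc3)=NN2C(=O)c2ccc(Cl)nc2)c2ccccc21`: > 300000 nM (a limit)
Compound 2 `Cn1cc(C2CC(c3ccccc3)=NN2C(=O)c2cccnc2)c2cc(Br)ccc21`: > 300000 nM (a limit)
Compound 3 `COc1ccc(C2=NN(C(=O)c3ccc(OC)nc3)C(c3cn(C)c4ccc(OC)cc34)C2)cc1`: > 300000 nM (a limit)

All three values come from an ADME assay on HEK-293T cells (Homo sapiens) for cytotoxicity, read by MTT assay, with a stated time of 48 h; a lower number here means that less compound is tolerated, a higher number that more compound is tolerated. Compound 3 gives > 300000 nM, which is a limit and not a number. Going by the values given here, it shares this result with the other two measured compounds, as the limit of > 300000 nM in this assay, at which 3 of the 3 values shown sit, shows, so no measured compound has an exact value for comparison.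

Compound 4 `COc1cccc(C2=NN(C(=O)c3ccc(OC)nc3)C(c3cn(C)c4ccc(OC)cc34)C2)c1` has the same atoms as compound 3, joined differently. It carries 3-methoxyphenyl in place of 4-methoxyphenyl on a carbon with a double bond to nitrogen.

Among the compounds with values here, no measured pair differs in just one place, so no measured step guides this change. Within the data shown here, the only guide is the limit of > 300000 nM in this assay, at which 3 of the 3 values shown sit, which covers compound 1, compound 2 and compound 3 alike. The expected step of a number no higher from compound 3 to compound 4 (the limit leaves the size open) is none beyond the scatter, and this assay will probably again report only a limit. Compound 4 is estimated at 300000 nM, with an expected range from 150000 nM to 600000 nM.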

Compound 4, half-maximal cytotoxic concentration: > 300000 nM
Compound 4 gave a limit, no number (the forecaster's own chance of this, stated with the estimate: 85%); the middle value lies on the limit itself.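

In this assay compound 4 gives > 300000 nM, which is a limit. Going by these compounds alone, compound 3 gives > 300000 nM, also a limit, so no step between compound 3 and compound 4 can be read. The compounds shown leave open whether 3-methoxyphenyl in place of 4-methoxyphenyl changes how much compound is tolerated.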